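Swapping an Amine Substituent on a Sulfamate Amide Series

The source may hold more compounds than are shown below. What is called first, only, known or untested is meant among the compounds shown, and "the series" means these compounds.

Among the measured compounds shown here, the three compounds measured so far share one core and differ only in the amine group attached to an aromatic carbon para to a large group. In an assay on HEK293 cells for inhibition of Steryl-sulfatase (Homo sapiens), tested at 0.1 uM (on this read-out higher numbers stand for a stronger effect at the one concentration tested and lower numbers for a weaker effect), compound 1 `CN(CCCN1CCCCC1)c1ccc(C(=O)N2CCc3ccc(OS(N)(=O)=O)cc3C2)cc1` gives 17.4% and stands second highest of the three numbers, with compound 3 `NS(=O)(=O)Oc1ccc2c(c1)CN(C(=O)c1ccc(N3CCCCC3)cc1)CC2` nearest at 11.5% and compound 2 `CCN(Cc1cccc(Br)c1)c1ccc(C(=O)N2CCc3ccc(OS(N)(=O)=O)cc3C2)cc1` furthest at 80.2%.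

Compound 4 `CCN(Cc1cccnc1)c1ccc(C(=O)N2CCc3ccc(OS(N)(=O)=O)cc3C2)cc1` is not yet measured. Its change from compound 1 is ethyl((pyridin-3-yl)methyl)amino in place of methyl(3-(piperidin-1-yl)propyl)amino on an aromatic carbon.

For the measured compounds named here, two measured steps bear on this change. The step of a number 62.8 percentage points higher from compound 1 to compound 2 (beyond the scatter) shows that placing an ethyl group together with an aromatic ring on the amine nitrogen gives a large rise. The step of a number 5.9 percentage points lower from compound 1 to compound 3 (within the scatter) shows that a plain piperidin-1-yl group changes little. Compound 4 carries an ethyl group and a (pyridin-3-yl)methyl group, so it resembles compound 2 more than compound 3, and a large rise in this assay is expected, though the aromatic ring here holds a nitrogen and lacks the bromine of compound 2, so the size is uncertain.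

Compound 4 is therefore expected to give 55%, within a range of 25% to 80%, a step of a number 37.6 percentage points higher from compound 1 to compound 4 (beyond the scatter) that is expected to be well beyond the scatter.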

Compound 4, a percentage reported as inhibition, at one concentration (the size of the read-out at that concentration, not a potency): 35.7%
For compound 4 the middle estimate is 19.3 percentage points above the measured one; the measured number falls inside the stated range.
By their numbers in this assay, from the lowest: compounds 3 and 1 (each within the scatter of the next); then compound 4; then compound 2.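

In this assay, the ethyl((pyridin-3-yl)methyl)amino group gives a number 18.3 percentage points higher from compound 1 to compound 4 (beyond the scatter) and a number 24.2 percentage points higher from compound 3 to compound 4 (beyond the scatter) against the two groups that carry no aromatic ring, so an aromatic ring on the amine at this position goes with a higher number even without bromine. Keeping the ethyl group and the saturated chain carbon while putting pyridin-3-yl in place of 3-bromophenyl gives a number 44.5 percentage points lower from compound 2 to compound 4 (beyond the scatter) in the same read-out. The ethyl group and an aromatic ring together are therefore not enough to reach the number of compound 2, and the nature of that ring strongly affects the result at one tested concentration.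

On these data alone, compound 2 and compound 4 differ in both the ring nitrogen and the bromine, so it remains open which of the two goes with the drop, and a plain benzyl group on the same ethyl-substituted amine would help separate them. Nothing available here explains why these changes shift inhibition.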